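The source may report more compounds than this note shows. Statements on the series, on what has been measured and on what is new or still open speak of the compounds shown alone.

Values measured so far in a functional assay on KYSE-410 cells (Homo sapiens) for antiproliferative activity, read by MTT assay, with a stated time of 72 h; on this read-out higher numbers stand for weaker inhibition and lower numbers for stronger inhibition:

- Compound 1 `O=C(Nc1ccc(Cl)cc1)c1cc(=O)[nH]c2cc(Br)ccc12` gives > 20000 nM, which is a limit.
- Compound 2 `O=C(Nc1ccc(OC(F)(F)F)cc1)c1cc(=O)[nH]c2cc(Br)ccc12` gives > 20000 nM, which is a limit.
- Compound 3 `CC(C)(C)c1ccc(NC(=O)c2cc(=O)[nH]c3cc(Br)ccc23)cc1` gives > 20000 nM, which is a limit.

Compound 1 therefore has no exact number, only a limit, and the same holds across the set, which shows (the limit of > 20000 nM in this assay, at which 3 of the 3 values shown sit). Compound 4 `O=C(Nc1cccc(Cl)c1)c1cc(=O)[nH]c2cc(Br)ccc12` keeps the core of compound 1 but has 3-chlorophenyl in place of 4-chlorophenyl on an amide-type nitrogen. The same atoms are present, joined differently.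

Three measured steps are the closest guides: a step that the two limits leave unreadable from compound 1 to compound 2, a step that the two limits leave unreadable from compound 1 to compound 3 and a step that the two limits leave unreadable from compound 2 to compound 3. Each exchanges one group for another on an aromatic carbon, and none moves the chlorine, so they bear on this change only indirectly. Among the measured compounds shown here, none of them has a readable size, which leaves no measured step to scale from. Compound 1 gives no number to start from either, so no change beyond the usual scatter is expected, and no direction can be favoured. The expected step is a number no higher from compound 1 to compound 4 (the limit leaves the size open). A report of only a limit is the most likely outcome for compound 4. If a number does appear, the estimate for compound 4 is 20000 nM, with an expected range from 8000 nM to 40000 nM.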

Compound 4, half-maximal inhibitory concentration: > 20000 nM
Compound 4 ended at the assay's limit; the forecaster's own chance of this, stated with the estimate: 75%; the middle value lies on the limit itself.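

No size can be read for the swap of 4-chlorophenyl for 3-chlorophenyl between compound 1 and compound 4, because each gives only a limit in this assay: the limit of > 20000 nM in this assay, at which 4 of the 4 values shown sit.

The compounds shown leave open whether the place of the chlorine matters at all, and which change to the core of compound 1 would give an exact number in this assay.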